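This account rests on a few compounds, and the source may have more. Where it says the series, first, only, none or still open, it means among the compounds named here.

Measured compounds:
- Compound 1, `CCCCCCCCc1ccc(OCC(=O)Cn2ncc3ccccc32)cc1`: in an assay on microsomes from brain for inhibition of Fatty-acid amide hydrolase 1 (Rattus norvegicus), read by fluorescence and HPLC, with a stated time of 60 min (a higher number here means a weaker inhibitor, a lower number a stronger inhibitor), compound 1 gives 2300 nM
- Compound 2, `O=C(COc1ccc(-c2ccccc2)cc1)Cn1nnc2ccccc21`: in this assay compound 2 gives 12 nM

Going by the values given here, of the two numbers known so far, compound 2 holds the lower one. Among the compounds with values here, its only neighbour, compound 1, shows a far higher number, and the gap between the two lies well beyond the usual scatter of this assay; compound 1 differs from compound 2 at more than one place, so no single step links them.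

Compound 3, `O=C(COc1ccc(-c2cccc(F)c2)cc1)Cn1nnc2ccccc21`, is not yet measured. It arises from compound 2 by one change: fluoro in place of hydrogen on an aromatic carbon, meta to a large group, so that the phenyl becomes a 3-fluorophenyl. Within the data shown here, no measured pair shows this change, so there is no step to read from. Given how small the added group is, the step from compound 2 to compound 3 in this assay is expected to stay within the scatter, with at most a slight move toward a lower number. The estimate for compound 3 is 10 nM, between 3 nM and 40 nM, corresponding to an expected 1.2-fold lower number from compound 2 to compound 3 (0.08 log units; within the scatter).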

Compound 3, half-maximal inhibitory concentration: 14 nM
Beside the measured number, compound 3's estimate is 1.4-fold (0.15 log units) below it; low and high end bracket the measured number.
By their numbers in this assay, from the lowest: compounds 2 and 3 (each within the scatter of the next); then compound 1.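

In this assay, fluoro in place of hydrogen on an aromatic carbon, which turns the phenyl into a 3-fluorophenyl, gives a 1.2-fold higher number from compound 2 to compound 3 (0.07 log units; within the scatter) and so leaves the number where it was. This is the only step shown that changes a single place, and it establishes what the pair of compound 1 and compound 2, which differ at more than one place, could not: a carbon of this six-membered aromatic ring, meta to a large group, can carry one fluorine atom while the number stays within the scatter of that of compound 2. Nothing given here bears on why the number holds at this position.

From the compounds shown here alone, whether the same holds for groups other than fluoro at this place, such as chloro, methoxy, trifluoromethyl, an amine or a carboxylic acid, remains open, and so does the outcome of fluoro on the other carbons of this ring. The wide gap between the numbers of compound 1 and compound 2 also remains unassigned to any one of the places where they differ.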